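From Benzyl to Phenoxy at the Assay Limit

This account rests on a few compounds, and the source may have more. Where it says the series, first, only, none or still open, it means among the compounds named here.

In a functional assay on HCT-116 cells (Homo sapiens) for cytotoxicity, read by MTT assay, with a stated time of 72 h (a lower number here means that less compound is tolerated, a higher number that more compound is tolerated), compound 1 `CCCCCn1c(=O)c(C(=O)Nc2cc([N+](=O)[O-])ccc2O)c(O)c2ccccc21` gives > 10000 nM, which is a limit of the assay and not a number. Compound 2 `Cn1c(=O)c(C(=O)O)c(O)c2cc(Cc3ccccc3)ccc21` gives > 10000 nM, and this too is only a limit. The record so far is therefore simply (the limit of > 10000 nM in this assay, at which 2 of the 2 values shown sit). Compound 3 `Cn1c(=O)c(C(=O)O)c(O)c2cc(Oc3ccccc3)ccc21` keeps the core of compound 2 but carries phenoxy in place of benzyl on an aromatic carbon. For the measured compounds named here, no measured pair shows what such a swap does, so the only guide is compound 2 and its limit of > 10000 nM. In this assay, no change beyond the usual scatter is expected, in either direction, and the estimated step is a step that the limit leaves unreadable from compound 2 to compound 3. For compound 3 the estimated value is 12000 nM, with an expected range from 6000 nM to 30000 nM, and the assay will most likely report only a limit again.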

Compound 3, half-maximal cytotoxic concentration: > 10000 nM
Compound 3 gave a limit, no number (the forecaster's own chance of this, stated with the estimate: 90%); the middle value lies beyond the limit too.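

Compound 2 and compound 3 each give only a limit in this assay, not a number, and no step can be read between them. Still open is whether phenoxy in place of benzyl on an aromatic carbon changes cytotoxicity at all, and at what concentration any of these compounds would become cytotoxic: the limit of > 10000 nM in this assay, at which 3 of the 3 values shown sit.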